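The compounds below may be only part of what the source reports. "The series", "measured", "known", "first", "only" and "open" are said of these compounds alone.

Series notes. Compound 1 `COc1ccc(F)cc1CNCCCNc1ccnc2cc(Cc3ccc(C#N)cc3)ccc12` gives 4200 nM in a physicochemical assay for solubility, with a stated time of 18 h, at pH 7.4; a lower number here means a less soluble compound, a higher number a more soluble compound. Compound 2 `COc1ccc(F)cc1CNCCCNc1ccnc2cc(CC(C)C)ccc12` gives 4200 nM, and compound 3 `COc1ccc(F)cc1CNCCCNc1ccnc2cc(Oc3ccc(Cl)cc3)ccc12` gives 14500 nM. Thus compound 1 stands level with compound 2 at the lowest of the three numbers, the step of no change at the digits printed from compound 1 to compound 2 (within the scatter) being within the scatter, while a 3.5-fold higher number from compound 1 to compound 3 (0.54 log units; beyond the scatter) and a 3.5-fold higher number from compound 2 to compound 3 (0.54 log units; beyond the scatter) are modest steps upward. All three measured steps alter the substituent on the core of compound 1; none touches the benzylic amine end.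

Compound 4 `N#Cc1ccc(Cc2ccc3c(NCCCNCc4ccco4)ccnc3c2)cc1` differs from compound 1 by furan-2-yl in place of 5-fluoro-2-methoxyphenyl on a saturated chain carbon bound to an amine nitrogen. Going by the values given here, no measured step bears on this position, so the expectation is a step of a 1.4-fold higher number from compound 1 to compound 4 (0.15 log units; within the scatter) in this assay, not beyond the scatter. Compound 4 is therefore estimated at 6000 nM, with a range of 2500 nM to 15000 nM.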

Compound 4, solubility: 4200 nM
For compound 4 the middle estimate is 1.4-fold (0.15 log units) above the measured one, and the stated range covers the measured number.
By their numbers in this assay, from the lowest: compounds 1, 2 and 4 (each within the scatter of the next); then compound 3.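

Going by these compounds alone, at the benzylic amine end, which no earlier step touched, no change at the digits printed from compound 1 to compound 4 (within the scatter) is the reading in this assay for furan-2-yl in place of 5-fluoro-2-methoxyphenyl. Here a five-membered aromatic ring with 1 hetero atom stands in for a six-membered aromatic ring of carbon only, with no difference beyond the scatter. No available evidence bears on this result. Open, as far as these compounds go, is whether a cyclohexyl group or a carboxylic acid at this place stays within the scatter of compound 1, and whether furan-2-yl reads the same alongside the 4-chlorophenoxy group of compound 3.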